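A few compounds are considered here, and "the series" means these few. Any claim that something is new, unique, unknown or untested is made for them only; others in the source may bear on it.

Measured in an ADME assay on L6 cells (Rattus norvegicus) for cytotoxicity; on this read-out lower numbers stand for stronger inhibition and higher numbers for weaker inhibition:
- compound 1 `COc1cc2c(cc1C(C)NCCCc1ccccc1)C=CC(C)(C)O2`: 1080 nM
- compound 2 `COc1ccc(CNC(C)c2cc3c(cc2OC)OC(C)(C)C=C3)cc1`: 14900 nM
- compound 3 `COc1cc2c(cc1C(C)N[C@H](C)c1ccccc1)C=CC(C)(C)O2`: 15900 nM

Compound 3 sits level with compound 2 within the usual scatter, and both numbers lie well above that of compound 1. The next compound, compound 4 `CCNC(C)c1cc2c(cc1OC)OC(C)(C)C=C2`, carries hydrogen in place of phenyl on a saturated chain carbon bound to an amine nitrogen and a saturated chain carbon, so 1-phenylethyl becomes ethyl: hydrogen in place of phenyl on a saturated chain carbon bound to an amine nitrogen and a saturated chain carbon. Among the compounds with values here, the one measured step, a 14-fold higher number from compound 1 to compound 2 (1.14 log units; beyond the scatter), is large and bears on this change only indirectly, showing that swapping one side group for another can move the number far in this assay. Within the data shown here, no measured compound goes without an aromatic ring in that chain, so there is no direct precedent. With compound 2 at 14900 nM and compound 3 at 15900 nM, only a small move towards a higher number is expected. The estimated step is a 1.9-fold higher number from compound 3 to compound 4 (0.28 log units; within the scatter). For compound 4 the estimated value is 30000 nM, with an expected range of 9000 nM to 100000 nM.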

Compound 4, half-maximal inhibitory concentration: 176000 nM
Estimate against measurement, compound 4: 5.9-fold (0.77 log units) below, and the stated range ends below it.
By their numbers in this assay, from the lowest: compound 1; then compounds 2 and 3 (each within the scatter of the next); then compound 4.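

In this assay, the change from 1-phenylethyl to ethyl, hydrogen in place of phenyl on a saturated chain carbon bound to an amine nitrogen and a saturated chain carbon, gives an 11-fold higher number from compound 3 to compound 4 (1.04 log units; beyond the scatter). Within the data shown here, compound 4 is the first compound here with no aromatic ring in that chain, and the other two routes to it run the same way: methyl in place of 4-methoxyphenyl gives a 12-fold higher number from compound 2 to compound 4 (1.07 log units; beyond the scatter), and hydrogen in place of benzyl gives a 160-fold higher number from compound 1 to compound 4 (2.21 log units; beyond the scatter). Among these four compounds, all three that keep an aromatic ring in the chain stand at lower numbers than compound 4, and none goes against this.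

As far as these compounds go, whether a cyclohexyl group or a butyl chain would sit nearer to ethyl or to the aromatic groups stays open. Nothing given here bears on the reason for these steps.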